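Methoxy to trifluoromethoxy on the shared core

This account rests on a few compounds, and the source may have more. Where it says the series, first, only, none or still open, it means among the compounds named here.

In a functional assay on HepG2 cells (Homo sapiens) for inhibition, read by sulforhodamine B assay, with a stated time of 74 h (on this read-out higher numbers stand for weaker inhibition and lower numbers for stronger inhibition), compound 1 `Cc1ccc(S(=O)(=O)N2C(=O)COC23C=CC(=O)C=C3)cc1` reads > 10000 nM, which is a limit of the assay and not a number. Compound 2 `O=C1C=CC2(C=C1)OCC(=O)N2S(=O)(=O)c1ccc(Cl)cc1` gives 860 nM and compound 3 `COc1ccc(S(=O)(=O)N2C(=O)COC23C=CC(=O)C=C3)cc1` gives 1620 nM, so these two stand level: a 1.9-fold higher number from compound 2 to compound 3 (0.28 log units; within the scatter). Compound 4 `O=C1C=CC2(C=C1)OCC(=O)N2S(=O)(=O)c1ccc(OC(F)(F)F)cc1` carries trifluoromethyl in place of methyl on an oxygen on an aromatic ring. Going by the values given here, no measured step makes this exact change. Replacing methyl on an aromatic carbon gave a large step, an at least 11-fold lower number from compound 1 to compound 2 (1.06 log units; beyond the scatter), and an at least modest one, an at least 6.1-fold lower number from compound 1 to compound 3 (0.79 log units; beyond the scatter). Among the compounds with values here, exchanging chloro and methoxy, the closest precedent, stayed within the scatter, so no step beyond the scatter is expected here. The estimated step in this assay is a 1.6-fold lower number from compound 3 to compound 4 (0.21 log units; within the scatter). Compound 4 is expected at 1000 nM, with an estimated range of 350 nM to 3000 nM.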

Compound 4, half-maximal inhibitory concentration: > 10000 nM
Compound 4: no number, only a limit; the forecaster's own chance of this, stated with the estimate: 5%; middle value at least 10-fold (1.00 log units) away from the limit.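

On the oxygen on an aromatic ring, trifluoromethyl in place of methyl gives the first step shown towards weaker inhibition in this assay: an at least 6.1-fold higher number from compound 3 to compound 4 (0.79 log units; beyond the scatter). Set against chloro, trifluoromethoxy gives an at least 11-fold higher number from compound 2 to compound 4 (1.06 log units; beyond the scatter), so trifluoromethoxy does not stand level with chloro and methoxy. Compound 4 gives a limit and not a number: the limit of > 10000 nM in this assay, at which 2 of the 4 values shown sit.

The step from compound 1 to compound 4 cannot be read. Going by these compounds, whether an amine or a longer alkoxy chain on that aromatic carbon would stay level with chloro and methoxy remains open.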